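The compounds below may be only part of what the source reports. "The series", "measured", "known", "first", "only" and "open" are said of these compounds alone.

Measured compounds:
Compound 1 `Cc1oc(-c2ccccc2Cl)nc1CN1CCC(C(=O)NCCCN2C[C@H](C)C[C@H](C)C2)CC1` — in a physicochemical assay for solubility, in phosphate buffer, measured as kinetic solubility, at pH 7.4 (on this read-out lower numbers stand for lower solubility and higher numbers for higher solubility), compound 1 gives a limit of > 72 ug/mL rather than a number.
Compound 2 `Cc1ccccc1-c1nc(CN2CCC(C(=O)NCCCN3CCCC(C(C)C)C3)CC2)c(C)o1` — in this assay compound 2 gives a limit of > 71 ug/mL, again a limit and not a number.
Compound 3 `Cc1cccc(Cl)c1-c1nc(CN2CCC(C(=O)NCCCN3CCC(C(C)C)CC3)CC2)c(C)o1` — in this assay compound 3 gives a limit of > 76 ug/mL, also a limit.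

Compound 1 therefore stands nowhere in particular among the numbers shown: its own value is a limit, and the two further values shown are limits as well, as the records (the limit of > 72 ug/mL in this assay, at which 1 of the 3 values shown sits), the limit of > 71 ug/mL in this assay, at which 1 of the 3 values shown sits, and the limit of > 76 ug/mL in this assay, at which 1 of the 3 values shown sits, make plain. None of the three compounds is separated from another by anything that can be read as a step, and no order among them can be claimed.

Compound 4 `Cc1cc(C)cc(-c2nc(CN3CCC(C(=O)NCCCN4C[C@H](C)C[C@H](C)C4)CC3)c(C)o2)c1` has not yet been measured in this assay. Compared with compound 1 the change is 3,5-dimethylphenyl in place of 2-chlorophenyl on an aromatic carbon. The rest of the shared core of compound 1 is kept.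

With every shown value sitting at a limit, the account can only set an expectation. The step from compound 1 to compound 4 is expected to be no more than the scatter, and it is estimated as an at least 1.0-fold lower number from compound 1 to compound 4 (0.01 log units; that floor lies within the scatter). Compound 4 is thus expected to come out near 70 ug/mL, within a range from 30 ug/mL to 160 ug/mL, and it may well again be reported only as a limit.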

Compound 4, solubility: > 71 ug/mL
Compound 4: no number, only a limit (the forecaster's own chance of this, stated with the estimate: 55%); middle value at least 1.0-fold (0.00 log units) from the limit.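

In this assay compound 4 gives > 71 ug/mL, a limit and not a number. Compound 1 likewise gives only a limit, so no step can be read between compound 1 and compound 4. The compounds shown leave open whether 3,5-dimethylphenyl in place of 2-chlorophenyl shifts this read-out at all, as neither compound has a number.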